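Benzyl ether series: ring substitution and whole-organism inhibition

The source may hold more compounds than are shown below. What is called first, only, known or untested is meant among the compounds shown, and "the series" means these compounds.

compound 1 `c1ccc(COc2nc3ccccc3s2)cc1` — 68.8%
compound 2 `Cc1ccc(COc2nc3ccccc3s2)cc1` — 1.95%
compound 3 `N#Cc1ccc(COc2nc3ccccc3s2)cc1` — 12.7%

All three numbers come from a functional assay on the whole organism with Mus musculus as the target, with a stated time of 1 h, at a dose of 100 mg/kg by the intraperitoneal route; a higher number here means more inhibition at the dose given (going by the name of the read-out), a lower number less inhibition. Compound 1 stands highest of the three; its nearest neighbour is compound 3 and the furthest is compound 2, both gaps beyond the scatter. Each change made so far on the benzyl ring of the shared core lowers the number: a number 66.9 percentage points lower from compound 1 to compound 2 (beyond the scatter), and a number 56.1 percentage points lower from compound 1 to compound 3 (beyond the scatter). Between the two substituted compounds, a number 10.8 percentage points higher from compound 2 to compound 3 (beyond the scatter).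

Compound 4 `Clc1ccccc1COc1nc2ccccc2s1` differs from compound 1 in one place: chloro in place of hydrogen on an aromatic carbon. Among the measured compounds shown here, the two measured steps from compound 1 are the only evidence that bears on this change; both put a single group on the same six-membered ring and both were large and downward. They bear only loosely, since the chloro enters ortho to a large group, not at the position held by methyl in compound 2 and cyano in compound 3. On this evidence a downward step beyond the scatter is expected, a number 38.8 percentage points lower from compound 1 to compound 4 (beyond the scatter), with wide uncertainty because the placement is new to the series. Compound 4 is therefore estimated at 30%, within a range from 5% to 70%.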

Compound 4, a percentage reported as inhibition, in the whole organism at one dose (the size of the read-out at that dose, not a potency): 14.6%
Compound 4: middle estimate off by 15.4 percentage points, on the high side, within the range that was stated.
By their numbers in this assay, from the lowest: compound 2; then compounds 3 and 4 (each within the scatter of the next); then compound 1.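

In this assay, chloro in place of hydrogen on an aromatic carbon, ortho to a large group, gives a number 54.2 percentage points lower from compound 1 to compound 4 (beyond the scatter). This is the series' first reading at this placement, and it shows that the loss is not confined to the position held by the methyl of compound 2 and the cyano of compound 3: a single chloro ortho to a large group also takes the number far down from that of compound 1, so all three substituted compounds shown lie well under the unsubstituted parent and none goes against this. Nothing available explains the size of this step, and the result gives no account of what the chloro does at this place.

On these data alone, whether fluoro, methoxy or hydroxyl at this same place would bring the same loss stays open, as does whether an amine or a carboxylic acid on this ring would follow the three groups seen so far. Also open, as far as these compounds go, is whether any group at all on this six-membered ring can keep the number of compound 1, or whether the unsubstituted ring stands alone.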